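Swapping 4-hydroxycyclohexyl for 3,4-dihydroxyphenyl on compound 2

A few compounds are considered here, and "the series" means these few. Any claim that something is new, unique, unknown or untested is made for them only; others in the source may bear on it.

Compound 1 `COc1ccc(Oc2ccc(C(C)C)cc2-c2ccsc2S(=O)(=O)NCCNC(=O)Nc2cc(Cl)cc(Cl)c2)cc1OC` gives 11900 nM
Compound 2 `O=C(NCCNS(=O)(=O)c1ccc(-c2ccccc2O[C@H]2CC[C@@H](O)CC2)s1)Nc1cc(C(F)(F)F)cc(C(F)(F)F)c1` gives 14100 nM
Compound 3 `O=C(Nc1ccc([N+](=O)[O-])cc1)N1CCN(S(=O)(=O)c2sccc2-c2ccccc2Oc2ccc(O)c(O)c2)CC1` gives > 20000 nM (a limit, not a number)

In an ADME assay on HEK-293T cells (Homo sapiens) for cytotoxicity, read by CCK-8 assay, with a stated time of 48 h (on this read-out lower numbers stand for stronger inhibition and higher numbers for weaker inhibition), compound 2 (14100 nM) lies within the usual scatter of compound 1 (11900 nM). Compound 3 has no exact number, and its entry (> 20000 nM) is a limit of the assay. Compound 4 `O=C(NCCNS(=O)(=O)c1ccc(-c2ccccc2Oc2ccc(O)c(O)c2)s1)Nc1cc(C(F)(F)F)cc(C(F)(F)F)c1` differs from compound 2 by having 3,4-dihydroxyphenyl in place of 4-hydroxycyclohexyl on an oxygen on an aromatic ring. Among the measured compounds shown here, no measured pair shows this change alone, so no step beyond the scatter is expected from compound 2. In this assay compound 2 gives 14100 nM. The expected change is small (a 1.2-fold lower number from compound 2 to compound 4 (0.07 log units; within the scatter)). The estimate for compound 4 is 12000 nM (expected range 5000 nM to 20000 nM).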

Compound 4, half-maximal inhibitory concentration: 17100 nM
The estimate for compound 4 lay 1.4-fold (0.15 log units) below the measured number; measured number inside the range.
By their numbers in this assay, from the lowest: compounds 1, 2 and 4 (each within the scatter of the next). At a limit, above all of these: compound 3.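

Among the compounds shown here, the first comparison in one place comes with this change, and in this assay it reads a 1.2-fold higher number from compound 2 to compound 4 (0.08 log units; within the scatter). On this oxygen, the read-out therefore does not separate the non-aromatic 4-hydroxycyclohexyl, with its defined stereocentres, from the aromatic 3,4-dihydroxyphenyl. Compound 3 gives a limit of the assay, not a number: the limit of > 20000 nM in this assay, at which 1 of the 4 values shown sits.

Going by these compounds, whether a simple methyl group, an amine or a carboxylic acid in this place would read any differently stays open. So does whether this change would give the same result on a different core.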